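Sulfonyl aryl changes and the step to compound 4

This account rests on a few compounds, and the source may have more. Where it says the series, first, only, none or still open, it means among the compounds named here.

compound 1 `Cn1c(=O)c(S(=O)(=O)c2ccc(O)cc2)cc2cnc(Nc3ccc4[nH]ccc4c3)nc21`: 100 nM
compound 2 `Cc1ccc(S(=O)(=O)c2cc3cnc(Nc4ccc5[nH]ccc5c4)nc3n(C)c2=O)cc1`: 750 nM
compound 3 `Cn1c(=O)c(S(=O)(=O)c2ccc(Br)cc2)cc2cnc(Nc3ccc4[nH]ccc4c3)nc21`: 5000 nM

In a functional assay on K562 cells (Homo sapiens) for inhibition, read by trypan blue exclusion, with a stated time of 72 h (on this read-out higher numbers stand for weaker inhibition and lower numbers for stronger inhibition), compound 3 gives 5000 nM and stands highest of the three, which makes it the weakest of the measured compounds. The unmeasured compound 4 `Cn1c(=O)c(S(=O)(=O)c2ccc([N+](=O)[O-])cc2F)cc2cnc(Nc3ccc4[nH]ccc4c3)nc21` differs from it in one place: 2-fluoro-4-nitrophenyl in place of 4-bromophenyl on a sulfonyl sulfur with the shared core unchanged.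

Going by the values given here, three measured steps bear on this change, each a swap of one group on an aromatic carbon of the same ring. The largest is a 50-fold higher number from compound 1 to compound 3 (1.70 log units; beyond the scatter) and the other two, a 7.5-fold higher number from compound 1 to compound 2 (0.88 log units; beyond the scatter) and a 6.7-fold higher number from compound 2 to compound 3 (0.82 log units; beyond the scatter), are modest. So the group on this ring clearly moves the number in this assay, but no measured compound carries a nitro group or a fluorine, and the direction for compound 4 cannot be read directly. Since compound 3 at 5000 nM already sits at the top of the series, a move down is thought more likely than a further rise. The expected change is a 2.5-fold lower number from compound 3 to compound 4 (0.40 log units; beyond the scatter) and would be small, toward stronger inhibition, with wide uncertainty. For compound 4 the estimate is 2000 nM with an expected range from 300 nM to 10000 nM as its upper end.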

Compound 4, half-maximal inhibitory concentration: 200 nM
Beside the measured number, compound 4's estimate is 10-fold (1.00 log units) above it, and the stated range ends above it.
By their numbers in this assay, from the lowest: compounds 1 and 4 (each within the scatter of the next); then compound 2; then compound 3.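

In this assay, replacing the aryl group on the sulfonyl sulfur gives a 25-fold lower number from compound 3 to compound 4 (1.40 log units; beyond the scatter) and a 3.8-fold lower number from compound 2 to compound 4 (0.57 log units; beyond the scatter), so the range of this position extends to a group with no hydroxy and the ring now reaches the low end of the series with 2-fluoro-4-nitrophenyl. The further comparison gives a 2.0-fold higher number from compound 1 to compound 4 (0.30 log units; within the scatter), which leaves compound 1 and compound 4 indistinguishable, so among the compounds shown a hydroxy group is not the only substituent that reaches this level. Nothing shown accounts for the size of these steps.

The compounds shown leave open how much of the change belongs to the fluorine and how much to the nitro group, as the two enter together in compound 4 and neither appears alone on the ring. Also open, from the compounds shown here alone, is how an amine or a carboxylic acid on this ring would read in this assay, and whether either would fall with compound 1 and compound 4 or nearer to compound 3.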